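From 2-methylphenyl to 4-methoxyphenyl: What Size of Step?

A few compounds are considered here, and "the series" means these few. Any claim that something is new, unique, unknown or untested is made for them only; others in the source may bear on it.

In a functional assay on LoVo cells (Homo sapiens) for inhibition, read by MTT assay, with a stated time of 24 h (on this read-out higher numbers stand for weaker inhibition and lower numbers for stronger inhibition), compound 3 `Cc1ccccc1-n1cc(CN2C(=O)C[C@@H]3CC[C@@]2(C)C3(C)C)nn1` gives 80 nM, and compound 1 `CC1(C)[C@H]2CC[C@]1(C)N(Cc1cn(-c3cccc(F)c3)nn1)C(=O)C2` gives 90 nM. These two match, with a 1.1-fold lower number from compound 1 to compound 3 (0.05 log units; within the scatter). Compound 2 `CC1(C)[C@H]2CC[C@]1(C)N(Cc1cn(-c3cccc(O)c3)nn1)C(=O)C2` gives 410 nM, and a 5.1-fold lower number from compound 2 to compound 3 (0.71 log units; beyond the scatter) separates it from compound 3. Compound 4 `COc1ccc(-n2cc(CN3C(=O)C[C@@H]4CC[C@@]3(C)C4(C)C)nn2)cc1` has 4-methoxyphenyl in place of 2-methylphenyl on an aromatic nitrogen. For the measured compounds named here, no measured step makes this exact swap. Going by the values given here, the closest guides are the one between the two oxygen-free groups, already given, and the one to the hydroxy compound, a 4.6-fold higher number from compound 1 to compound 2 (0.66 log units; beyond the scatter). The hydroxy group is a different group in a different place, so it guides only loosely. A modest move to a higher number is expected, estimated as a 2.0-fold higher number from compound 3 to compound 4 (0.30 log units; within the scatter). Compound 4 is estimated at 160 nM, with an expected range of 60 nM to 450 nM.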

Compound 4, half-maximal inhibitory concentration: 70 nM
The estimate for compound 4 lay 2.3-fold (0.36 log units) above the measured number, within the range that was stated.
By their numbers in this assay, from the lowest: compounds 4, 3 and 1 (each within the scatter of the next); then compound 2.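

In this assay, 4-methoxyphenyl on the aromatic nitrogen reads the same as the oxygen-free groups, with a 1.1-fold lower number from compound 3 to compound 4 (0.06 log units; within the scatter) and a 1.3-fold lower number from compound 1 to compound 4 (0.11 log units; within the scatter), so an oxygen-bearing group at this position need not raise the number. Compound 2 alone stands apart, with a 5.9-fold lower number from compound 2 to compound 4 (0.77 log units; beyond the scatter), which shows that the oxygen of its hydroxy group cannot by itself account for its higher number. No measurement here explains this gap. Still open, on these data alone, is whether that gap follows from the hydroxy group itself or from its place on the ring, and how an amine or a carboxylic acid on this phenyl ring would read.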